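The source may report more compounds than this note shows. Statements on the series, on what has been measured and on what is new or still open speak of the compounds shown alone.

Compound 1, `ClCc1cccc(Cn2cnc3c(Cl)ncnc32)c1`, gives 63100 nM in a functional assay on EKVX cells (Homo sapiens) for cytotoxicity, read by sulforhodamine B assay, with a stated time of 48 h; on this read-out lower numbers stand for higher toxicity in this test and higher numbers for lower toxicity in this test. Compound 2, `ClCc1ccc(Cn2cnc3nc(Cl)nc(Cl)c32)cc1`, gives 6300 nM. Compound 3, `ClCc1cccc(Cn2cnc3c(Cl)nc(Cl)nc32)c1`, gives 6450 nM.

Compound 2 and compound 3 are built from the same atoms joined differently; the difference between the two cores is not broken down here, and their two values lie within the usual scatter of each other. Going from compound 3 to compound 1, the change hydrogen in place of chloro on an aromatic carbon brought a 9.8-fold higher number from compound 3 to compound 1 (0.99 log units; beyond the scatter), so the compound became less toxic in this assay.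

Compound 4, `ClCc1ccc(Cn2cnc3ncnc(Cl)c32)cc1`, has not yet been measured. It arises from compound 2 by hydrogen in place of chloro on an aromatic carbon, the same change at the same kind of place. Within the data shown here, the step is therefore expected to be about a 9.5-fold higher number from compound 2 to compound 4 (0.98 log units; beyond the scatter), resting on a 9.8-fold higher number from compound 3 to compound 1 (0.99 log units; beyond the scatter) as the only measured example. Compound 4 is expected to give about 60000 nM in this assay, estimated to fall between 25000 nM and 140000 nM.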

Compound 4, concentration lethal to 50% of the cells: 8700 nM
Compound 4: middle estimate off by 6.9-fold (0.84 log units), on the high side; the measured number lies below the stated range.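

In this assay, hydrogen in place of chloro on an aromatic carbon brought a 1.4-fold higher number from compound 2 to compound 4 (0.14 log units; within the scatter), so on this core the change made no clear difference. The same change therefore did not carry over with the same size from one core to the other: the same change on two cores in this assay, a 9.8-fold higher number (0.99 log units; beyond the scatter) from compound 3 to compound 1 and a 1.4-fold higher number (0.14 log units; within the scatter) from compound 2 to compound 4, 7.1-fold (0.85 log units) apart, beyond the scatter of two such steps This shows that a step measured on one core is a poor guide to the same step on the other core in this series, but two examples cannot show why the steps differ or how the change would behave on any further core.

Only chloro and hydrogen appear on this aromatic carbon in the compounds shown. Going by these compounds, how an amine or a methoxy group there would read in this assay stays open.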